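A 3-Methoxyphenyl Analogue in the Trimethoxyphenyl Triazole Series

A few compounds are considered here, and "the series" means these few. Any claim that something is new, unique, unknown or untested is made for them only; others in the source may bear on it.

The series shares one core, a trimethoxyphenyl bound to a triazole that carries a second aryl ring. Compound 1 `COc1cc(-n2ncnc2-c2cccc([N+](=O)[O-])c2)cc(OC)c1OC` bears a nitrophenyl on that ring. In a functional assay on HeLa cells (Homo sapiens) for antiproliferative activity, read by MTT assay, with a stated time of 72 h (a higher number here means a weaker inhibitor, a lower number a stronger inhibitor), compound 1 gives only the limit > 10000 nM. Compound 2 `COc1cc(-n2ncnc2-c2ccc(F)cc2)cc(OC)c1OC` carries a 4-fluorophenyl instead. In this assay compound 2 likewise reaches only the limit > 10000 nM. Compound 3 `COc1cc(-n2ncnc2-c2cccc(Cl)c2)cc(OC)c1OC` carries a 3-chlorophenyl. In this assay compound 3 also stands at the limit > 10000 nM, so it cannot be placed above or below its two companions on the numbers shown. The step that the two limits leave unreadable from compound 1 to compound 3 and the step that the two limits leave unreadable from compound 2 to compound 3 are therefore both unreadable, because every value sits at the limit of > 10000 nM in this assay, at which 3 of the 3 values shown sit.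

Compound 4 `COc1cccc(-c2ncnn2-c2cc(OC)c(OC)c(OC)c2)c1` is the unmeasured member. It differs from compound 3 by methoxy in place of chloro on an aromatic carbon. Among the measured compounds shown here, no measured step in this assay can be read for size or direction, so the two unreadable steps give no guidance on the size of this change. With all three known values at the limit, the expected step of an at least 1.2-fold lower number from compound 3 to compound 4 (0.09 log units; that floor lies within the scatter) is small or none beyond the scatter. Compound 4 is estimated to give 8000 nM in this assay, within a range of 1500 nM to 30000 nM.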

Compound 4, half-maximal inhibitory concentration: > 10000 nM
Compound 4 gave a limit, no number; the forecaster's own chance of this, stated with the estimate: 55%; middle value at least 1.2-fold (0.09 log units) away from the limit.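

In this assay compound 4 gives > 10000 nM, which is a limit and not a number. Its steps from compound 1, compound 2 and compound 3 cannot be read, because all four compounds stand at the same limit: the limit of > 10000 nM in this assay, at which 4 of the 4 values shown sit. The compounds shown leave open how these four rank against one another in this assay.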